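Trimethoxy to dimethoxy on the pendant aryl: growth inhibition

This account rests on a few compounds, and the source may have more. Where it says the series, first, only, none or still open, it means among the compounds named here.

Measured compounds:
- compound 1, `COc1ccc(-c2cc(/C=C/C(=O)c3ccc(N)cc3)[nH]n2)cc1`: "not determined" (no result reported) in a functional assay on HOP-92 cells (Homo sapiens) for inhibition, read by sulforhodamine B assay, with a stated time of 48 h; a lower number here means a stronger inhibitor of growth, a higher number a weaker inhibitor of growth
- compound 2, `COc1cc(-c2cc(/C=C/C(=O)c3ccc(N)cc3)[nH]n2)cc(OC)c1OC`: 3680 nM

Among the compounds with values here, compound 2 carries the only number in this assay, giving 3680 nM. Compound 1 carries "not determined" (no result reported) in this assay, so nothing can be said about the step from compound 1 to compound 2 beyond the fact that one side of it is empty.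

Compound 3, `COc1ccc(-c2cc(/C=C/C(=O)c3ccc(N)cc3)[nH]n2)cc1OC`, is the next entry and has not been run in this assay. It differs from compound 2 in one place: hydrogen in place of methoxy on an aromatic carbon. The rest of the shared core, the enone linker and the aminophenyl ketone are kept as in compound 2.

Within the data shown here, no step between two measured compounds exists in this set, so there is no measured precedent for the loss of one methoxy here. The expectation is a step within the usual scatter, with a slight lean toward weaker inhibition. The step of a 1.2-fold higher number from compound 2 to compound 3 (0.09 log units; within the scatter) that this estimate implies is expected to be small. Compound 3 is expected to give 4500 nM in this assay, with a plausible range from 1500 nM to 14000 nM.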

Compound 3, concentration for 50% growth inhibition: 1490 nM
Estimate against measurement, compound 3: 3.0-fold (0.48 log units) above; the measured number lies below the stated range.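

In this assay, within the data shown here, hydrogen in place of methoxy on this aromatic carbon gives a 2.5-fold lower number from compound 2 to compound 3 (0.39 log units; beyond the scatter), the first measured step and one that lies beyond the usual scatter. The position ortho to a methoxy group and meta to a large group therefore does not need its methoxy for growth inhibition in this cell line, as compound 3 at 1490 nM is the stronger inhibitor of growth of the pair, with only the methoxy changed and the remainder of the structure kept. Nothing available bears on why the number falls with this change.

On these data alone, the step from compound 3 to compound 1 cannot be read, so it remains open whether taking away a further methoxy from the same ring would lower the number again, leave it unchanged or raise it. As far as these compounds go, it is also open whether the gain belongs to hydrogen itself or would survive with a hydroxyl, a fluorine atom, an ethoxy group or an amine on this aromatic carbon.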